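Amide nitrogen substituent series: working notes

The source may hold more compounds than are shown below. What is called first, only, known or untested is meant among the compounds shown, and "the series" means these compounds.

Measured so far in an assay on HEK293 cells for agonist activity at transient receptor potential cation channel subfamily M member 8 (Homo sapiens), read by fluorescence and calcium flux, with a stated time of 15 min; on this read-out lower numbers stand for an effect already at smaller amounts and higher numbers for an effect only at larger amounts of compound:
- compound 1 `Cc1ccc(OCC(=O)N(Cc2cccs2)c2ncco2)cc1` gives 0.3 nM
- compound 2 `Cc1ccc(OCC(=O)N(Cc2cccs2)C2COC2)cc1` gives 23000 nM
- compound 3 `Cc1ccc(OCC(=O)N(Cc2cccs2)c2ccncc2)cc1` gives 52 nM

Compound 3 stands second of the three numbers in this assay. Its nearest neighbour is compound 1, and the step of a 170-fold higher number from compound 1 to compound 3 (2.24 log units; beyond the scatter) is large; its furthest is compound 2, with the step of a 440-fold lower number from compound 2 to compound 3 (2.65 log units; beyond the scatter) also large. The step of a 77000-fold higher number from compound 1 to compound 2 (4.88 log units; beyond the scatter) frames the full spread of the three.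

Compound 4 `CCCN(Cc1cccs1)C(=O)COc1ccc(C)cc1` is not yet measured. The change is propyl in place of pyridin-4-yl on an amide-type nitrogen. Within the data shown here, no measured step replaces the pyridin-4-yl with an open chain, so the closest guide is compound 2, whose oxetan-3-yl likewise carries no aromatic ring and gives 23000 nM, far from compound 3. On that basis a large step towards higher numbers in this assay is expected for compound 4, of roughly the size seen from compound 3 to compound 2, i.e. a 380-fold higher number from compound 3 to compound 4 (2.59 log units; beyond the scatter). Compound 4 is therefore estimated at 20000 nM, within a range of 3000 nM to 100000 nM, with a real chance that only a limit is reported.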

Compound 4, half-maximal effective concentration: 40 nM
The estimate for compound 4 lay 500-fold (2.70 log units) above the measured number; the whole stated range lies above it.
By their numbers in this assay, from the lowest: compound 1; then compounds 4 and 3 (each within the scatter of the next); then compound 2.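

In this assay, an aromatic ring on the amide-type nitrogen is not required to reach the level of compound 3: the open-chain propyl gives a number within the scatter of pyridin-4-yl (a 1.3-fold lower number from compound 3 to compound 4 (0.11 log units; within the scatter)). The high number of compound 2 therefore cannot be put down simply to the lack of an aromatic ring, as oxetan-3-yl and propyl, neither of them aromatic, stand far apart (a 580-fold lower number from compound 2 to compound 4 (2.76 log units; beyond the scatter)). The low number of compound 1 remains specific to 1,3-oxazol-2-yl among these groups (a 130-fold higher number from compound 1 to compound 4 (2.12 log units; beyond the scatter)), and compound 3 shows that an aromatic ring alone does not reproduce it.

No measurement at hand accounts for any of these steps. On these data alone, whether a butyl chain, an isopropyl group or a chain ending in an amine would stay with compound 4 or move towards compound 1 or compound 2 remains open.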